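Methoxy in Place of Nitro: Estimating Compound 4

A few compounds are considered here, and "the series" means these few. Any claim that something is new, unique, unknown or untested is made for them only; others in the source may bear on it.

Compound 1 `O=C(/C=C/c1ccc([N+](=O)[O-])cc1)Nc1cc(Sc2ncn[nH]2)c(O)c2ccccc12`: 40.6%
Compound 2 `O=C(Nc1cc(Sc2ncn[nH]2)c(O)c2ccccc12)c1cccc([N+](=O)[O-])c1`: 29.3%
Compound 3 `COc1ccc(/C=C/C(=O)Nc2cc(Sc3ncn[nH]3)c(O)c3ccccc23)cc1OC`: 31.7%

In an assay on isolated protein for inhibition of RAC-alpha serine/threonine-protein kinase (Homo sapiens), read by fluorescence, with a stated time of 30 min, tested at 10 uM (on this read-out lower numbers stand for less inhibition and higher numbers for more inhibition at the one concentration tested (going by the name of the read-out)), compound 2 gives the smallest of the three numbers; its gap to compound 3 lies within the scatter, while its gap to compound 1 lies beyond it. Compound 4 `COc1cccc(C(=O)Nc2cc(Sc3ncn[nH]3)c(O)c3ccccc23)c1` is not yet measured and differs from compound 2 by methoxy in place of nitro on an aromatic carbon. Among the measured compounds shown here, the only single-site step among the measured compounds is a number 8.9 percentage points lower from compound 1 to compound 3 (within the scatter), a swap of one aryl substituent pattern for another that left the read-out essentially unchanged. For the measured compounds named here, no measured step swaps nitro for methoxy on the same ring, so the expectation rests on that one aryl change alone. On this basis compound 4 is expected at 27%, between 12% and 42%, which would mean an expected step of a number 2.3 percentage points lower from compound 2 to compound 4 (within the scatter), not beyond the scatter.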

Compound 4, a percentage reported as inhibition, at one concentration (the size of the read-out at that concentration, not a potency): 19.4%
Compound 4: the middle estimate sits 7.6 percentage points above what was measured; the measured number falls inside the stated range.
By their numbers in this assay, from the lowest: compounds 4, 2, 3 and 1 (each within the scatter of the next, the first and the last beyond it).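

In this assay, among the compounds shown here, the swap from 3-nitrophenyl to 3-methoxyphenyl gives the first direct reading of methoxy in place of nitro at this ring carbon: a number 9.9 percentage points lower from compound 2 to compound 4 (within the scatter). At this position, the change therefore cannot be told apart from the scatter, and neither compound 2 nor compound 4 can be placed ahead of the other. Nothing available here accounts for the size of the step. As far as these compounds go, whether an amine or a carboxylic acid at this position would move the read-out beyond the scatter remains open. So does whether methoxy in place of nitro would read alike with the longer double-bonded chain of compound 1.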